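Methoxy in Place of Fluoro: Expected Cytotoxicity of Compound 4

The source may report more compounds than this note shows. Statements on the series, on what has been measured and on what is new or still open speak of the compounds shown alone.

Compound 3 `CC(=O)c1cc(-c2ccc(F)cc2)cc2cc(-c3ccc(F)cc3)[nH]c12` gives 13800 nM in a functional assay on HeLa cells (Homo sapiens) for cytotoxicity, read by MTT assay, with a stated time of 2 days (on this read-out higher numbers stand for lower toxicity in this test and lower numbers for higher toxicity in this test), the lowest of the two numbers recorded. Compound 1 `CC(=O)c1cc(-c2ccc(F)cc2)cc2cc(-c3ccccc3)[nH]c12` gives 38000 nM in this assay. For compound 2 `CC(=O)c1cc(-c2ccccc2)cc2cc(-c3ccc(F)cc3)[nH]c12`, this assay reports only a limit, > 100000 nM. Both measured steps bring in fluoro and lower the number: a 2.8-fold lower number from compound 1 to compound 3 (0.44 log units; beyond the scatter), and an at least 7.2-fold lower number from compound 2 to compound 3 (0.86 log units; beyond the scatter). Compound 4 `COc1ccc(-c2cc3cc(-c4ccc(F)cc4)cc(C(C)=O)c3[nH]2)cc1` differs from compound 3 by methoxy in place of fluoro on an aromatic carbon. Removing the fluoro runs against the direction of an at least 7.2-fold lower number from compound 2 to compound 3 (0.86 log units; beyond the scatter), though methoxy rather than hydrogen enters, and a smaller rise in the number is therefore expected. Compound 4 is estimated at 30000 nM, with a range from 10000 nM to 100000 nM. This estimate means an expected step of a 2.2-fold higher number from compound 3 to compound 4 (0.34 log units; beyond the scatter).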

Compound 4, concentration lethal to 50% of the cells: 42800 nM
Beside the measured number, compound 4's estimate is 1.4-fold (0.15 log units) below it; the measured number falls inside the stated range.
By their numbers in this assay, from the lowest: compound 3; then compounds 1 and 4 (each within the scatter of the next). At a limit, above all of these: compound 2.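

In this assay, the change from 4-fluorophenyl to 4-methoxyphenyl gives a 3.1-fold higher number from compound 3 to compound 4 (0.49 log units; beyond the scatter), so the lower number seen with fluoro does not carry over to methoxy at this position. Methoxy and hydrogen cannot be told apart here: a 1.1-fold higher number from compound 1 to compound 4 (0.05 log units; within the scatter), leaving fluoro the only one of the three groups that stands apart. Nothing in the data shown accounts for this difference. As far as these compounds go, whether chloro, an amine or a carboxylic acid in this place would side with fluoro or with hydrogen stays open.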